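The source may report more compounds than this note shows. Statements on the series, on what has been measured and on what is new or still open speak of the compounds shown alone.

Working notes on the series, all compared on the shared core of compound 1 `CC(C)=CC[C@@H](OC(=O)c1ccco1)C1=CC(=O)c2c(O)ccc(O)c2C1=O` in a functional assay on DU-145 cells (Homo sapiens) for cytotoxicity, read by MTT assay; a lower number here means a stronger inhibitor, a higher number a weaker inhibitor. Compound 1 gives > 100000 nM, which is a limit of the assay and not a number. Compound 2 `COC(C)CO[C@H](CC=C(C)C)C1=CC(=O)c2c(O)ccc(O)c2C1=O` gives 16600 nM, and compound 3 `CCCCC(O)CC(=O)O[C@H](CC=C(C)C)C1=CC(=O)c2c(O)ccc(O)c2C1=O` gives 45300 nM. Compound 3 therefore has the higher of the two actual numbers, and compound 2 is its nearest neighbour, with a 2.7-fold higher number from compound 2 to compound 3 (0.44 log units; beyond the scatter).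

The next change leads to compound 4 `CC(=O)OCCO[C@H](CC=C(C)C)C1=CC(=O)c2c(O)ccc(O)c2C1=O` and is 2-acetoxyethyl in place of (2-hydroxyhexyl)carbonyl on an oxygen on a saturated carbon. In words, 2-acetoxyethyl stands in place of (2-hydroxyhexyl)carbonyl on an oxygen on a saturated carbon. For the measured compounds named here, the closest precedent is the step between compound 2 and compound 3, since compound 2 also has a 2-methoxypropyl group on that oxygen rather than a group joined through a carbonyl. Read in reverse, a 2.7-fold higher number from compound 2 to compound 3 (0.44 log units; beyond the scatter) points to a modest fall. The steps of an at least 6.0-fold lower number from compound 1 to compound 2 (0.77 log units; beyond the scatter) and an at least 2.2-fold lower number from compound 1 to compound 3 (0.34 log units; beyond the scatter) add little, as both start from the limit of > 100000 nM in this assay, at which 1 of the 3 values shown sits, and give no full size. With a single close precedent, a modest move towards a lower number in this assay is expected, possibly close to the scatter. The expected step is a 2.1-fold lower number from compound 3 to compound 4 (0.31 log units; beyond the scatter). Compound 4 is estimated at 22000 nM, with an expected range of 8000 nM to 60000 nM.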

Compound 4, half-maximal inhibitory concentration: 15500 nM
Estimate against measurement, compound 4: 1.4-fold (0.15 log units) above; low and high end bracket the measured number.
By their numbers in this assay, from the lowest: compounds 4 and 2 (each within the scatter of the next); then compound 3. At a limit, above all of these: compound 1.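

In this assay, placing 2-acetoxyethyl for (2-hydroxyhexyl)carbonyl on an oxygen on a saturated carbon gives a 2.9-fold lower number from compound 3 to compound 4 (0.47 log units; beyond the scatter) and supplies a second compound without a carbonyl directly on that oxygen; both such compounds, 2 and 4, carry lower numbers than compound 3, and no compound shown goes against this. The change of acetoxymethyl for 1-methoxyethyl on a saturated chain carbon bound to an oxygen on a saturated carbon gives a 1.1-fold lower number from compound 2 to compound 4 (0.03 log units; within the scatter) and so does not separate the two groups, even though only 2-acetoxyethyl carries an ester carbonyl further along the chain. Compound 1 remains a limit and not a number, so an at least 6.4-fold lower number from compound 1 to compound 4 (0.80 log units; beyond the scatter) sets only a bound on the size of that step: the limit of > 100000 nM in this assay, at which 1 of the 4 values shown sits.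

The step from compound 3 to compound 4 alters both the link to the oxygen and the chain, which leaves open which of the two accounts for it. Also open, on these data alone, is how a longer ether chain, or a chain bearing an amine or a carboxylic acid, would read on this oxygen.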